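Working notes: isopropyl in place of dimethylamino

The compounds below may be only part of what the source reports. "The series", "measured", "known", "first", "only" and "open" are said of these compounds alone.

Compound 1 `COc1ccc(/C=C2/S/C(=N/c3ccccc3)N(Cc3ccncc3)C2=O)cc1` gives 47900 nM in an ADME assay on HEK293 cells (Homo sapiens) for cytotoxicity, read by MTT assay, with a stated time of 48 h; on this read-out higher numbers stand for weaker inhibition and lower numbers for stronger inhibition
Compound 2 `CN(C)c1ccc(/C=C2/S/C(=N/c3ccccc3)N(Cc3ccncc3)C2=O)cc1` gives 122000 nM in this assay

Of the two measured compounds, compound 2 stands highest at 122000 nM and compound 1 is its nearest neighbour, with the lower number. The next change leads to compound 3 `CC(C)c1ccc(/C=C2/S/C(=N/c3ccccc3)N(Cc3ccncc3)C2=O)cc1` and reads isopropyl in place of dimethylamino on an aromatic carbon with isopropyl in place of dimethylamino on an aromatic carbon, para to a large group.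

Among the compounds with values here, only one measured step bears on this change. The step of a 2.5-fold higher number from compound 1 to compound 2 (0.41 log units; beyond the scatter) is modest and beyond the scatter, and in it dimethylamino enters, whereas here dimethylamino leaves. No measurement with isopropyl exists, so this is a weak guide. In this assay a modest move to a lower number is expected on losing the group that compound 2 carries at 122000 nM and not much more than that. The expected step is a 2.2-fold lower number from compound 2 to compound 3 (0.35 log units; beyond the scatter) and its size is uncertain. The estimated value for compound 3 is 55000 nM (expected range 20000 nM to 140000 nM).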

Compound 3, half-maximal inhibitory concentration: 137000 nM
The estimate for compound 3 lay 2.5-fold (0.40 log units) below the measured number; the measured number falls inside the stated range.
By their numbers in this assay, from the lowest: compound 1; then compounds 2 and 3 (each within the scatter of the next).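

In this assay the exchange gives a 1.1-fold higher number from compound 2 to compound 3 (0.05 log units; within the scatter) and so shows that, at this position, dimethylamino and isopropyl cannot be told apart on this read-out, even though the nitrogen and the hydrogen-bond acceptor counted for dimethylamino are gone in isopropyl. The comparison with methoxy gives a 2.9-fold higher number from compound 1 to compound 3 (0.46 log units; beyond the scatter) and places isopropyl with dimethylamino on the same side of compound 1, so among these three groups methoxy alone stands apart, with the lower number, and neither the nitrogen of dimethylamino nor the all-carbon isopropyl separates compound 2 from compound 3 here. The data on these compounds offer no information on why methoxy differs from the other two groups.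

From the compounds shown here alone, three groups at one position make a narrow set, and it remains open whether a hydroxyl, a primary amine or a carboxylic acid at this place would fall with compound 1 or with compounds 2 and 3. Going by these compounds, it is equally open whether a longer alkoxy chain such as ethoxy or butoxy would keep the lower number of compound 1 in this assay or move towards the numbers of compounds 2 and 3.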